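From primary amide to acyl sulfonamide in one step

This account rests on a few compounds, and the source may have more. Where it says the series, first, only, none or still open, it means among the compounds named here.

Compound 1, `Cc1n[nH]c(C(N)=O)c1Cc1cccc(-c2ccc(F)cc2)c1`: 1%
Compound 2, `Cc1nn(C)c(C(=O)O)c1Cc1cccc(-c2ccc(F)cc2)c1`: 5%

Both were tested in an assay on isolated protein for inhibition of 2-Hydroxyacid oxidase 2 (Homo sapiens), tested at 1 uM; on this read-out lower numbers stand for a weaker effect and higher numbers for a stronger effect at the one concentration tested. Compound 1 gives 1%, the lowest of the two numbers, and compound 2 gives 5%, a number within the scatter of it, so the two cannot be told apart. Within the data shown here, no step between measured compounds is at hand.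

Compound 3, `Cc1n[nH]c(C(=O)NS(C)(=O)=O)c1Cc1cccc(-c2ccc(F)cc2)c1`, differs from compound 1 by methylsulfonyl in place of hydrogen on an amide-type nitrogen. With compound 1 at 1% and nothing else to lean on, no change beyond the scatter is expected, and the expected step of a number 4 percentage points higher from compound 1 to compound 3 (within the scatter) is therefore small. Compound 3 is estimated at 5%, within -5% to 20%.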

Compound 3, a percentage reported as inhibition, at one concentration (the size of the read-out at that concentration, not a potency): 8%
The estimate for compound 3 lay 3 percentage points below the measured number; low and high end bracket the measured number.
By their numbers in this assay, from the lowest: compounds 1, 2 and 3 (each within the scatter of the next).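

In this assay, methylsulfonyl in place of hydrogen on the amide-type nitrogen gives a number 7 percentage points higher from compound 1 to compound 3 (within the scatter) and so brings no change that can be told from the scatter. This nitrogen therefore carries the methylsulfonyl without a clear gain or loss on this read-out at the one concentration tested. Nothing at hand bears on why this is so. As far as these compounds go, whether an acetyl or phenylsulfonyl group on the same nitrogen would move the read-out beyond the scatter stays open. So does whether compound 3 has any real effect at all in this assay.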